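Chain extension from compound 2 to compound 3

This account rests on a few compounds, and the source may have more. Where it says the series, first, only, none or still open, it means among the compounds named here.

Among the measured compounds shown here, in a physicochemical assay for lipophilicity (a higher number here means a more lipophilic compound, a lower number a more polar compound), compound 1 (`CCOC(=O)c1cccc(S(N)(=O)=O)c1`) gives 1.11 and compound 2 (`CCCCOC(=O)c1cccc(S(N)(=O)=O)c1`) gives 2.24, the higher of the two numbers so far. Compound 3 (`CCCCCOC(=O)c1cccc(S(N)(=O)=O)c1`) differs from it by methyl in place of hydrogen on a saturated chain carbon, four bonds along the chain from an oxygen next to a carbonyl group. For the measured compounds named here, the only measured step that bears on this is a number 1.13 log units higher from compound 1 to compound 2 (beyond the scatter), with ethyl entering the same chain. Methyl is the smaller group, so a smaller step than that one is expected, upward in this assay. The expected step is a number 0.56 log units higher from compound 2 to compound 3 (beyond the scatter). For compound 3 the estimate is 2.8, with an expected range of 2.5 to 3.1.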

Compound 3, partition coefficient: 2.71
Estimate against measurement, compound 3: 0.09 log units above; the range from low to high includes it.
By their numbers in this assay, from the lowest: compound 1; then compound 2; then compound 3.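

In this assay the rise does not stop at butyl: a number 0.47 log units higher from compound 2 to compound 3 (beyond the scatter), so methyl in place of hydrogen four bonds along the chain from an oxygen next to a carbonyl group still moves the number beyond the scatter. Taken as one change, propyl in place of hydrogen two bonds along the chain gives a number 1.60 log units higher from compound 1 to compound 3 (beyond the scatter), the largest step in the series so far. Nothing measured accounts for the size of either step. On these data alone, whether a longer chain such as hexyl continues the rise remains open, as does the step given by a chain carrying an amine.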